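Para-substituent series: hydroxy replaces fluoro on compound 2

A few compounds are considered here, and "the series" means these few. Any claim that something is new, unique, unknown or untested is made for them only; others in the source may bear on it.

Compound 1 `COc1ccc(-c2noc(-c3ccc(Cl)cc3)n2)cc1OC1CCCC1` and compound 2 `COc1ccc(-c2noc(-c3ccc(F)cc3)n2)cc1OC1CCCC1` share a core and differ only in the substituent on the outer phenyl ring. In a functional assay on DU-145 cells (Homo sapiens) for antiproliferative activity, read by MTT assay, with a stated time of 24 h (a lower number here means a stronger inhibitor, a higher number a weaker inhibitor), compound 1 gives 123000 nM, while compound 2 gives 20700 nM. For the measured compounds named here, the one measured step, a 5.9-fold lower number from compound 1 to compound 2 (0.77 log units; beyond the scatter), is the only comparison available, and it leaves compound 2 with the lowest number of the two, clear of compound 1 by that margin.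

Compound 3 `COc1ccc(-c2noc(-c3ccc(O)cc3)n2)cc1OC1CCCC1` is not yet measured. Relative to compound 2 it carries the change (hydroxy in place of fluoro on an aromatic carbon), at the same place on the ring where the halogen exchange occurred. Going by the values given here, no measured step involves a hydroxy group, so the halogen step bears on this change only in showing that the para position is sensitive to what sits there. On that basis, compound 3 is expected to land near compound 2, with the step of a 1.4-fold lower number from compound 2 to compound 3 (0.14 log units; within the scatter) estimated as small. The estimated value for compound 3 is 15000 nM, within 4000 nM to 60000 nM.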

Compound 3, half-maximal inhibitory concentration: 780 nM
Estimate against measurement, compound 3: 19-fold (1.28 log units) above; measured number below the stated range.
By their numbers in this assay, from the lowest: compound 3; then compound 2; then compound 1.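

In this assay, the step from 4-fluorophenyl to 4-hydroxyphenyl, a 27-fold lower number from compound 2 to compound 3 (1.42 log units; beyond the scatter), is large, whereas the halogen exchange, a 5.9-fold lower number from compound 1 to compound 2 (0.77 log units; beyond the scatter), was modest, so this position, para to a large group, responds much more to hydroxy than the two halogens alone could show. Measured against the chloro end of the series, a 160-fold lower number from compound 1 to compound 3 (2.20 log units; beyond the scatter), the hydroxy group separates compound 3 from both halogen compounds by more than the scatter. No supporting measurement is available to explain this gain.

Going by these compounds, it remains open whether the low number is specific to hydroxy or is shared by other groups at this place, such as an amine or a carboxylic acid. Also open, on these data alone, is whether the gain from hydroxy persists when other parts of the shared core are changed.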